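Swapping fluoro for hydroxy at one end

The compounds below may be only part of what the source reports. "The series", "measured", "known", "first", "only" and "open" are said of these compounds alone.

Of the compounds shown here, two have been measured so far in a functional assay on HOP-62 cells (Homo sapiens) for inhibition, read by sulforhodamine B assay; a lower number here means a stronger inhibitor of growth, a higher number a weaker inhibitor of growth. Compound 1 (`Oc1ccc(-c2ccc(-c3ccc(-c4nc5ccccc5[nH]4)cc3)cc2)cc1`) gives 47200 nM, and compound 2 (`Oc1cccc2[nH]c(-c3ccc(-c4ccc(-c5ccc(F)cc5)cc4)cc3)nc12`) gives 8310 nM. Compound 2 therefore holds the lower of the two numbers, and the gap between them lies beyond the usual scatter, making it the stronger inhibitor of growth of this pair.

The next compound to be measured is compound 3 (`Oc1ccc(-c2ccc(-c3ccc(-c4nc5c(O)cccc5[nH]4)cc3)cc2)cc1`), which differs from compound 2 at a single place: hydroxy in place of fluoro on an aromatic carbon. In words, this is hydroxy in place of fluoro on an aromatic carbon, turning 4-fluorophenyl into 4-hydroxyphenyl. Going by the values given here, no measured pair shows this change alone, as compound 1 and compound 2 differ in more than one place, so any forecast is uncertain. Among the compounds with values here, the only guide is compound 1, which carries the same 4-hydroxyphenyl end and reads 47200 nM in this assay, pointing towards a higher number. A modest weakening is therefore expected, estimated as a 1.9-fold higher number from compound 2 to compound 3 (0.28 log units; within the scatter). For compound 3 the estimated value is 16000 nM, with an expected range from 5000 nM to 50000 nM.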

Compound 3, concentration for 50% growth inhibition: 2410 nM
Compound 3: the middle estimate sits 6.6-fold (0.82 log units) above what was measured; measured number outside the range, below it.
By their numbers in this assay, from the lowest: compound 3; then compound 2; then compound 1.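

In this assay the change from 4-fluorophenyl to 4-hydroxyphenyl can now be read alone, and it gives a 3.4-fold lower number from compound 2 to compound 3 (0.54 log units; beyond the scatter) so the hydroxy at this end goes with stronger inhibition of growth than the fluoro in this pair. A second single change can also be read: with the 4-hydroxyphenyl end held the same, adding a hydroxy to the core gives a 20-fold lower number from compound 1 to compound 3 (1.29 log units; beyond the scatter) and this large step is the bigger of the two. The high number of compound 1 therefore cannot be pinned on the 4-hydroxyphenyl end alone, as compound 3 keeps that end and has the lowest number of the three.

Going by these compounds alone, nothing measured so far accounts for the direction or the size of either step. Still open, on these data alone, is how an amine or a methoxy group would read in place of the hydroxy at this end, and whether the hydroxy on the core would give a step of similar size alongside the 4-fluorophenyl end.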